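Replacing Benzyloxy in a Series Held at a Limit

The source may report more compounds than this note shows. Statements on the series, on what has been measured and on what is new or still open speak of the compounds shown alone.

- compound 1 `C=C[C@@](C)(/C=C/c1ccc(OCc2ccccc2)cc1)CCC=C(C)C` gives > 26000 nM as a limit
- compound 2 `C=C[C@@](C)(/C=C/c1ccc(O)cc1)CC/C=C/C(=O)OCc1ccccc1` gives > 26000 nM as a limit
- compound 3 `C=C[C@@](C)(/C=C/c1ccc(O)c(/C=C/c2ccc(Cl)cc2)c1)CCC=C(C)C` gives > 26000 nM as a limit

In a functional assay on Raji cells (Homo sapiens) for cytotoxicity, with a stated time of 72 h (on this read-out higher numbers stand for an effect only at larger amounts of compound and lower numbers for an effect already at smaller amounts), compound 1 gives > 26000 nM as its result, which is a limit and not a number. The whole set offers no firmer figure, only the limit of > 26000 nM in this assay, at which 3 of the 3 values shown sit, to go on. Compound 4 `C=C[C@@](C)(/C=C/c1ccc(Nc2ccc(OC)cc2)cc1)CCC=C(C)C` has not yet been measured. Its change from compound 1 is this: (4-methoxyphenyl)amino in place of benzyloxy on an aromatic carbon, with (4-methoxyphenyl)amino in place of benzyloxy on an aromatic carbon. Going by the values given here, no measured pair differs in one place, so the only anchor is compound 1 at > 26000 nM and no clear direction is expected. The expected change in this assay is none beyond the scatter, with a number no higher from compound 1 to compound 4 (the limit leaves the size open) as the estimated step. For compound 4 the estimate is 26000 nM, with an expected range from 10000 nM to 50000 nM.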

Compound 4, half-maximal effective concentration: > 26000 nM
Compound 4: a limit, no number (the forecaster's own chance of this, stated with the estimate: 70%); the middle value lies on the limit itself.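

Compound 1 and compound 4 both give a limit and not a number, so the step between them cannot be read. The compounds shown leave open which change to the shared core would yield a measurable value, as every result rests on one limit: the limit of > 26000 nM in this assay, at which 4 of the 4 values shown sit.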